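The source may hold more compounds than are shown below. What is called first, only, known or untested is meant among the compounds shown, and "the series" means these compounds.

Compound 1, `Cc1occc1-c1nnc(SCC(=O)Nc2ccc(F)c(Cl)c2)n1Cc1ccco1`, was tested in a functional assay on CHO cells for antagonist activity at Orexin receptor type 2 (Homo sapiens), read by FLIPR and calcium flux (a higher number here means a weaker inhibitor, a lower number a stronger inhibitor), where compound 1 gives 39.8 nM. Compound 2, `Cc1ccc(NC(=O)CSc2nnc(-c3ccoc3C)n2Cc2ccco2)cc1`, gives 39.8 nM in this assay, and compound 3, `Cc1occc1-c1nnc(SCC(=O)Nc2ccc(Cl)cc2)n1Cc1ccco1`, gives 100 nM. Compound 1 thus sits level with compound 2, the two together at the lowest numbers of the three, while compound 3 stands at a higher number: no change at the digits printed from compound 1 to compound 2 (within the scatter), and a 2.5-fold higher number from compound 1 to compound 3 (0.40 log units; beyond the scatter). The remaining pair shows a 2.5-fold higher number from compound 2 to compound 3 (0.40 log units; beyond the scatter).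

Compound 4, `Cc1occc1-c1nnc(SCC(N)=O)n1Cc1ccco1`, is the compound still to be measured. (hydrogen in place of 3-chloro-4-fluorophenyl on an amide-type nitrogen). Among the compounds with values here, every measured step so far only exchanged groups on that aromatic ring; none of them removed the ring itself, so they bear on the new step only loosely. They show that exchanging groups on the ring moves the number by a modest amount, as in a 2.5-fold higher number from compound 1 to compound 3 (0.40 log units; beyond the scatter). Taking away the whole ring and leaving a bare amide nitrogen is a far larger change than any of those. Without a comparable measured step, the expectation is that the number in this assay rises by a large amount, with wide uncertainty: a 130-fold higher number from compound 1 to compound 4 (2.10 log units; beyond the scatter) is the step expected. Compound 4 is therefore estimated at 5000 nM, expected to lie between 800 nM and 30000 nM, with a real chance that only a limit is reported.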

Compound 4, inhibition constant: > 15800 nM
Compound 4 was reported as a limit; the forecaster's own chance of this, stated with the estimate: 35%; middle value at least 3.1-fold (0.49 log units) away from the limit.
By their numbers in this assay, from the lowest: compounds 1 and 2 (each within the scatter of the next); then compound 3. At a limit, above all of these: compound 4.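

The earlier compounds shown here only exchanged groups on the aromatic ring carried by the amide-type nitrogen, and in this assay those exchanges gave modest steps at most, leaving open what happens when the ring itself is gone. Compound 4, with hydrogen on that nitrogen in place of the ring, is reported only as a limit and not as a number: the limit of > 15800 nM in this assay, at which 1 of the 4 values shown sits. All three steps to it are large, namely an at least 390-fold higher number from compound 1 to compound 4 (2.59 log units; beyond the scatter), an at least 390-fold higher number from compound 2 to compound 4 (2.59 log units; beyond the scatter) and an at least 150-fold higher number from compound 3 to compound 4 (2.19 log units; beyond the scatter), so in this small set, removing the whole ring costs far more than any change among the groups on it.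

From the compounds shown here alone, since compound 4 is a limit, the true size of these steps remains unknown, and they can only be read as minimum sizes. The compounds shown also leave open how much of the lost inhibition would return with something between hydrogen and a substituted phenyl on this nitrogen, such as a methyl group, an unsubstituted phenyl ring or a saturated cyclohexyl ring.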